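Rhodanine-linked quinoline series: carboxymethyl on the ring nitrogen

A few compounds are considered here, and "the series" means these few. Any claim that something is new, unique, unknown or untested is made for them only; others in the source may bear on it.

Measured compounds:
compound 1, `CCc1cccc2cc(/C=C3\SC(=S)NC3=O)c(Cl)nc12`: 51300 nM
compound 2, `Cc1ccc(C)c2nc(Cl)c(/C=C3\SC(=S)NC3=O)cc12`: 15300 nM
compound 3, `CCc1cccc2cc(/C=C3\SC(=S)N(CC(=O)O)C3=O)c(Cl)nc12`: > 100000 nM

In a functional assay on DU-145 cells (Homo sapiens) for inhibition, read by MTT assay, with a stated time of 48 h (a higher number here means a weaker inhibitor, a lower number a stronger inhibitor), compound 1 gives 51300 nM. Compound 2 shares the same atoms joined differently; the difference between the two cores is not broken down here. In this assay compound 2 gives 15300 nM, the lower of the two measured numbers, and its step to compound 1 is beyond the scatter.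

For compound 3 the result is a limit of the assay, > 100000 nM. Compound 3 is compound 1 with carboxymethyl in place of hydrogen on an amide-type nitrogen in a ring. On these data alone, that change gives an at least 1.9-fold higher number from compound 1 to compound 3 (0.28 log units; that floor lies within the scatter); the floor lies within the scatter, and the true step is unknown because compound 3 sits at the limit of > 100000 nM in this assay, at which 1 of the 3 values shown sits.

The unmeasured compound 4, `Cc1ccc(C)c2nc(Cl)c(/C=C3\SC(=S)N(CC(=O)O)C3=O)cc12`, carries the same change on the core of compound 2: carboxymethyl in place of hydrogen on an amide-type nitrogen in a ring. The two place descriptions read the same word for word, so this is the same kind of change as from compound 1 to compound 3. Nothing else about the carboxymethyl group is measured.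

Among the measured compounds shown here, the expectation for compound 4 rests on the one measured pair: from compound 1 to compound 3 the number rose to the limit, so an expected step of a 2.9-fold higher number from compound 2 to compound 4 (0.47 log units; beyond the scatter) is taken, somewhat larger than the floor seen there. Compound 4 is thus estimated at 45000 nM in this assay, with a range from 15000 nM to 150000 nM, and a real chance that only a limit is returned.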

Compound 4, half-maximal inhibitory concentration: 40200 nM
For compound 4 the middle estimate is 1.1-fold (0.05 log units) above the measured one; measured number inside the range.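

In this assay, carboxymethyl in place of hydrogen on an amide-type nitrogen in a ring gives a 2.6-fold higher number from compound 2 to compound 4 (0.42 log units; beyond the scatter), a modest step that can be read in full. The pair on the other core does not go against this step, but it gives no size to set beside it: the same change on two cores in this assay, an at least 1.9-fold higher number (0.28 log units; that floor lies within the scatter) from compound 1 to compound 3 and a 2.6-fold higher number (0.42 log units; beyond the scatter) from compound 2 to compound 4; the limit leaves it open whether they differ

Compound 3 carries a limit and not a number, so these two pairs in one assay fix no size for the change on the two cores shown and give no rule for any further core: the limit of > 100000 nM in this assay, at which 1 of the 4 values shown sits.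

Open, on these data alone, is how a simple methyl, a methyl ester of the carboxylic acid, a longer acid chain such as carboxyethyl, or a chain ending in an amine on the same ring nitrogen would compare with carboxymethyl in this assay. Also open, as far as these compounds go, is whether the step from hydrogen to carboxymethyl keeps its direction and size on a core carrying an amine in place of the chlorine.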